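The source may hold more compounds than are shown below. What is called first, only, known or untested is meant among the compounds shown, and "the series" means these compounds.

Compound 1 `CCN(CCCCOc1ccc(/C=C/C(=O)c2ccc(N(C)C)cc2O)cc1)Cc1ccccc1OC` and compound 2 `CCN(CCCCOc1ccc(/C=C/C(=O)c2ccc(N(C)C)cc2O)cc1)Cc1ccccc1N(C)C` share one core, while compound 3 `CCN(CCCCCCOc1ccc(C(=O)/C=C/c2ccc(N(C)C)cc2)c(O)c1)Cc1ccccc1OC` and compound 4 `CCN(CCCCCCOc1ccc(C(=O)/C=C/c2ccc(N(C)C)cc2)c(O)c1)Cc1ccccc1N(C)C` share another; the difference between the two cores is not broken down here. In an assay on isolated protein for inhibition of Amine oxidase [flavin-containing] B (Homo sapiens) (on this read-out lower numbers stand for stronger inhibition and higher numbers for weaker inhibition), compound 1 gives 4600 nM, and compound 2 gives 4300 nM. The change from compound 1 to compound 2 is dimethylamino in place of methoxy on an aromatic carbon, and it produced a 1.1-fold lower number from compound 1 to compound 2 (0.03 log units; within the scatter). In this assay compound 3 gives 700 nM, the lowest number of the three measured compounds, with its steps to compound 1 and compound 2 both beyond the usual scatter.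

Compound 4 carries the same change relative to compound 3: dimethylamino in place of methoxy on an aromatic carbon. Within the data shown here, the only measured example of this change, on the other core, left the number essentially unchanged, so compound 4 is expected to sit close to compound 3, with an expected step of a 1.1-fold lower number from compound 3 to compound 4 (0.03 log units; within the scatter) in this assay. This rests on compound 2 versus compound 1 because a 1.1-fold lower number from compound 1 to compound 2 (0.03 log units; within the scatter) lay within the scatter. Compound 4 is therefore estimated at 650 nM, with a range from 300 nM to 1500 nM.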

Compound 4, half-maximal inhibitory concentration: 2100 nM
For compound 4 the middle estimate is 3.2-fold (0.51 log units) below the measured one; measured number outside the range, above it.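

The change of 2-methoxybenzyl to 2-(dimethylamino)benzyl gave a 3.0-fold higher number from compound 3 to compound 4 (0.48 log units; beyond the scatter) in this assay, whereas on the other core it gave a 1.1-fold lower number from compound 1 to compound 2 (0.03 log units; within the scatter). The two results do not agree, so the near-absence of an effect on the core of compound 1 did not carry over to the core of compound 3: the same change on two cores in this assay, a 1.1-fold lower number (0.03 log units; within the scatter) from compound 1 to compound 2 and a 3.0-fold higher number (0.48 log units; beyond the scatter) from compound 3 to compound 4, 3.2-fold (0.51 log units) apart, beyond the scatter of two such steps. This shows that, for these two pairs, the outcome of the change depends on the core, but with a single pair on each core it does not show which difference between the cores is responsible, nor does it set a rule for the wider series.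

Going by these compounds, it remains open whether other groups on the same aromatic carbon, such as a hydroxyl, a chlorine or a primary amine, would also give different steps on the two cores. Also open, on these data alone, is whether a shorter or longer chain, with the rest of the core left unchanged, would alter the step.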